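The source may hold more compounds than are shown below. What is called first, only, known or untested is meant among the compounds shown, and "the series" means these compounds.

Working notes on the series. Two compounds share one core and differ only at the aromatic carbon carrying the halogen. Compound 1 `COc1cccc(OC)c1C(=O)Nc1nnc(-c2ccc(Cl)cc2)s1` gives 58.9 nM in a functional assay on the whole organism (integument) for inhibition, with Chilo suppressalis as the target, read by scintillation counting, with a stated time of 72 h, in the presence of a further agent that is not named here; on this read-out higher numbers stand for weaker inhibition and lower numbers for stronger inhibition. Compound 2 `COc1cccc(OC)c1C(=O)Nc1nnc(-c2ccc(Br)cc2)s1` gives 45.7 nM in this assay. Among the measured compounds shown here, the only step so far is a 1.3-fold lower number from compound 1 to compound 2 (0.11 log units; within the scatter), so compound 2 and compound 1 sit within the scatter of each other and neither is separated from the other.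

Compound 3 `COc1cccc(OC)c1C(=O)Nc1nnc(-c2ccc(C#N)cc2)s1` carries the change (cyano in place of bromo on an aromatic carbon). For the measured compounds named here, the one measured step that bears on it, a 1.3-fold lower number from compound 1 to compound 2 (0.11 log units; within the scatter), was a halogen-for-halogen exchange that stayed within the scatter; no measured step exchanges a halogen for a cyano group, so that step gives only a weak guide. On this basis no step beyond the scatter is expected in this assay, with a wide range to cover the unknown. For compound 3 the estimate is 60 nM, with a range from 20 nM to 180 nM. The expected step is a 1.3-fold higher number from compound 2 to compound 3 (0.12 log units; within the scatter).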

Compound 3, half-maximal inhibitory concentration: 200 nM
For compound 3 the middle estimate is 3.3-fold (0.52 log units) below the measured one, and the stated range ends below it.
By their numbers in this assay, from the lowest: compounds 2 and 1 (each within the scatter of the next); then compound 3.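

In this assay, this position is not indifferent to what it carries: exchanging one halogen for the other stayed within the scatter, but cyano in place of bromo gives a 4.4-fold higher number from compound 2 to compound 3 (0.64 log units; beyond the scatter) and cyano in place of chloro gives a 3.4-fold higher number from compound 1 to compound 3 (0.53 log units; beyond the scatter) as well. Both steps are modest but beyond the scatter, so compound 3 is the weakest of the three on this read-out, and the 4-cyanophenyl compound does not fall in with the two halogen compounds. Nothing available accounts for this loss of inhibition.

As far as these compounds go, whether the loss belongs to cyano alone or extends to other groups that are not halogens remains open, since a methoxy group, an amine or a carboxylic acid at this position would be needed to tell. Also open, from the compounds shown here alone, is whether fluoro or iodo would stay with chloro and bromo.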